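Amide substituent changes and cytotoxicity in the series

This account rests on a few compounds, and the source may have more. Where it says the series, first, only, none or still open, it means among the compounds named here.

Three compounds have been read in an ADME assay on SW480 cells (Homo sapiens) for cytotoxicity, read by MTT assay, with a stated time of 72 h; on this read-out lower numbers stand for stronger inhibition and higher numbers for weaker inhibition:
compound 1 `CCOc1ccc(NC(=O)c2cccc(/C=C3\CC(=O)N(Cc4ccccc4)C3=O)c2)cc1` gives 73200 nM;
compound 2 `COc1ccc(NC(=O)c2cccc(/C=C3\CC(=O)N(c4ccccc4)C3=O)c2)c(C)c1` gives only a limit of the assay, > 100000 nM;
compound 3 `CCCCNC(=O)c1cccc(/C=C2\CC(=O)N(Cc3ccccc3)C2=O)c1` gives only a limit of the assay, > 100000 nM.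

Compound 2 therefore stands at the limit (the limit of > 100000 nM in this assay, at which 2 of the 3 values shown sit), with no number of its own. The unmeasured compound 4 `O=C(c1cccc(/C=C2\CC(=O)N(c3ccccc3)C2=O)c1)N1CCCC1` differs from compound 2 in one place: pyrrolidin-1-yl in place of (4-methoxy-2-methylphenyl)amino on a carbonyl carbon. Among the compounds with values here, the one measured step that also changes the group on the amide-type nitrogen is an at least 1.3-fold higher number from compound 1 to compound 3 (0.13 log units; that floor lies within the scatter), which gives no resolved shift in this assay. That step ends at the limit of > 100000 nM in this assay, at which 2 of the 3 values shown sit, as well, so there is no sign that changing the amide substituent brings the number down. Compound 4 is expected to remain at that limit. The step is estimated at a step that the limit leaves unreadable from compound 2 to compound 4. For compound 4 the expected value in this assay is 110000 nM, in the range 50000 nM to 300000 nM, most likely reported as a limit only.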

Compound 4, half-maximal inhibitory concentration: > 100000 nM
Compound 4 gave a limit, no number; the forecaster's own chance of this, stated with the estimate: 75%; the middle value is on the limit's open side.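

No new step can be read: compound 2 and compound 4 both stand at a limit and carry no number of their own, so the change from (4-methoxy-2-methylphenyl)amino to pyrrolidin-1-yl has no readable size: the limit of > 100000 nM in this assay, at which 3 of the 4 values shown sit.

The compounds shown leave open whether any amide substituent on the core of compound 2 brings the number under that limit.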